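Swapping a Fused Ring for a Methylpyridine

The compounds below may be only part of what the source reports. "The series", "measured", "known", "first", "only" and "open" are said of these compounds alone.

Two related compounds have been tested in a functional assay on A549 cells (Homo sapiens) for antiproliferative activity, read by MTT assay, with a stated time of 48 h; a lower number here means a stronger inhibitor, a higher number a weaker inhibitor. Compound 1 `Clc1cccc(Nc2ncnc3ccc(NCc4c[nH]c5ccccc45)cc23)c1` gives 2330 nM in this assay. Compound 2 `O=C(/C=C/c1ncc2ccccc2n1)Nc1ccc2ncnc(Nc3cccc(Cl)c3)c2c1` gives 3350 nM, the highest of the two numbers, though its gap to compound 1 lies within the scatter. Compound 3 `Cc1cccc(/C=C/C(=O)Nc2ccc3ncnc(Nc4cccc(Cl)c4)c3c2)n1` differs from compound 2 by 6-methylpyridin-2-yl in place of quinazolin-2-yl on a double-bonded chain carbon bound to a double-bonded chain carbon. Among the measured compounds shown here, with no measured step of this kind to lean on, the expected shift from compound 2 to compound 3 is a 1.2-fold higher number from compound 2 to compound 3 (0.08 log units; within the scatter), close to no change beyond the scatter. Compound 3 is therefore estimated at 4000 nM, in a range from 1500 nM to 11000 nM.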

Compound 3, half-maximal inhibitory concentration: 2160 nM
Estimate against measurement, compound 3: 1.9-fold (0.27 log units) above, and the stated range covers the measured number.
By their numbers in this assay, from the lowest: compounds 3, 1 and 2 (each within the scatter of the next).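

In this assay, replacing the two-ring quinazolin-2-yl with the single-ring 6-methylpyridin-2-yl gives a 1.6-fold lower number from compound 2 to compound 3 (0.19 log units; within the scatter), so on this chain carbon one aromatic ring can go without a change beyond the scatter. Among the compounds shown here, this is the first measured swap at this position, and no measurement here accounts for the result. The compounds shown leave open what the methyl group contributes, since unsubstituted pyridin-2-yl is absent from them. They also leave open whether a non-aromatic group here, such as an amine or a carboxylic acid, would give a similar number.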